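Lactam ring expansion on the oxazole scaffold

This account rests on a few compounds, and the source may have more. Where it says the series, first, only, none or still open, it means among the compounds named here.

Measured so far:
compound 1, `CC(C)Oc1ccccc1N1CCN(Cc2cc(CN3CCCC3=O)no2)CC1`: 65.5 nM
compound 2, `CC(C)Oc1ccccc1N1CCN(Cc2nc(CN3CCCC3=O)co2)CC1`: > 5000 nM

In an assay on isolated protein for displacement of a labelled ligand from Alpha-1D adrenergic receptor (Homo sapiens) (a higher number here means a weaker inhibitor, a lower number a stronger inhibitor), compound 1 gives 65.5 nM. Compound 2 stands apart: in this assay compound 2 is reported only as a limit of the assay, > 5000 nM. Compound 2 is thus placed at the limit of > 5000 nM in this assay, at which 1 of the 2 values shown sits, so its position relative to compound 1 is known only as weaker than the numbered value, not by how much. For the measured compounds named here, no step between two measured compounds with a single point of difference is available, so the size of any single change has not been measured.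

Compound 3, `CC(C)Oc1ccccc1N1CCN(Cc2nc(CN3CCCCC3=O)co2)CC1`, is the next compound, derived from compound 2 by 2-oxopiperidin-1-yl in place of 2-oxopyrrolidin-1-yl on a saturated chain carbon bound to an aromatic carbon. Starting from a compound that shows only a limit, the expected step is a step that the limit leaves unreadable from compound 2 to compound 3, that is, none beyond the scatter, and most likely compound 3 will again sit at the limit. The inhibition constant of compound 3 in this assay is estimated at 7000 nM, with a range from 2000 nM to 25000 nM.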

Compound 3, inhibition constant: > 5000 nM
Compound 3: a limit, no number; the forecaster's own chance of this, stated with the estimate: 70%; the middle value lies beyond the limit too.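

Compound 2 and compound 3 are both reported only as limits of the assay, so no step between them can be read: the limit of > 5000 nM in this assay, at which 2 of the 3 values shown sit.

As far as these compounds go, what remains open is how far either compound lies beyond that limit in this assay, and what 2-oxopiperidin-1-yl in place of 2-oxopyrrolidin-1-yl does on the core of compound 1, which gives a number.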